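Hydroxamate Sulfonamides: Dimethoxyphenyl Gives Way to Nitrophenyl

The source may hold more compounds than are shown below. What is called first, only, known or untested is meant among the compounds shown, and "the series" means these compounds.

Among the compounds with values here, compound 2 `COc1ccc(S(=O)(=O)N2CCN(c3ncc(/C=C/C(=O)NO)s3)CC2)cc1OC` holds the higher of the two numbers measured so far. In a functional assay on MCF7 cells (Homo sapiens) for antiproliferative activity (on this read-out lower numbers stand for stronger inhibition of growth and higher numbers for weaker inhibition of growth), compound 2 gives 4000 nM, while compound 1 `O=C(/C=C/c1cnc(N2CCN(S(=O)(=O)c3ccc(-c4ccccc4)cc3)CC2)s1)NO` gives 1500 nM, a gap that lies beyond the usual scatter. Compound 3 `O=C(/C=C/c1cnc(N2CCN(S(=O)(=O)c3ccc([N+](=O)[O-])cc3)CC2)s1)NO` differs from compound 2 by 4-nitrophenyl in place of 3,4-dimethoxyphenyl on a sulfonyl sulfur. Within the data shown here, no measured pair shows this exact change, so the expected step of a 1.6-fold lower number from compound 2 to compound 3 (0.20 log units; within the scatter) is a modest move toward stronger inhibition, one that may still fall within the scatter. Compound 3 is therefore estimated at about 2500 nM, with a plausible range from 800 nM to 8000 nM.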

Compound 3, concentration for 50% growth inhibition: 5000 nM
Estimate against measurement, compound 3: 2.0-fold (0.30 log units) below; low and high end bracket the measured number.
By their numbers in this assay, from the lowest: compound 1; then compounds 2 and 3 (each within the scatter of the next).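

In this assay, 4-nitrophenyl in place of 3,4-dimethoxyphenyl on a sulfonyl sulfur gives a 1.3-fold higher number from compound 2 to compound 3 (0.10 log units; within the scatter) and so does not separate these two groups at this position. Nitro in place of phenyl on an aromatic carbon gives a 3.3-fold higher number from compound 1 to compound 3 (0.52 log units; beyond the scatter) and is the only single-place step here beyond the scatter, with the lower number on the biphenyl compound 1. Nothing available explains either step.

The compounds shown leave open how an amine or a pyridine ring would read on that aromatic carbon.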